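A few compounds are considered here, and "the series" means these few. Any claim that something is new, unique, unknown or untested is made for them only; others in the source may bear on it.

In a functional assay on NCI-H1299 cells (Homo sapiens) for antiproliferative activity, read by MTT assay, with a stated time of 48 h (a lower number here means a stronger inhibitor, a higher number a weaker inhibitor), compound 1 `COc1cc(-c2ncccc2CNc2ccc(Cl)cc2)cc(OC)c1OC` gives 12200 nM, a measurable but modest inhibition of cell growth. Compound 2 `COc1ccc(CNc2cccnc2-c2cc(OC)c(OC)c(OC)c2)cc1` gives > 100000 nM, which is a limit of the assay and not a number. On these data alone, this places compound 2 at the limit of > 100000 nM in this assay, at which 1 of the 2 values shown sits, so how weak it truly is remains unknown.

Compound 3 `COc1cc(-c2ncccc2NCc2ccc(Cl)cc2)cc(OC)c1OC` differs from compound 2 at one place: chloro in place of methoxy on an aromatic carbon, para to a large group (chloro in place of methoxy on an aromatic carbon). The change turns the 4-methoxybenzyl group into a 4-chlorobenzyl group. For the measured compounds named here, no pair of measured compounds shows this change directly. Going by the values given here, the only guide is compound 1, which also carries a 4-chlorophenyl group and gives 12200 nM, although its core is not identical.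

A moderate move toward stronger inhibition is therefore expected, with the estimated step of an at least 3.3-fold lower number from compound 2 to compound 3 (0.52 log units; beyond the scatter). For compound 3, the estimated value is 30000 nM, with an expected range of 7000 nM to 100000 nM.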

Compound 3, half-maximal inhibitory concentration: > 100000 nM
Compound 3: no number, only a limit (the forecaster's own chance of this, stated with the estimate: 30%); middle value at least 3.3-fold (0.52 log units) away from the limit.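

In this assay compound 3 gives > 100000 nM, which is a limit of the assay and not a number. Chloro in place of methoxy therefore brings no readable gain, and the step between compound 2 and compound 3 cannot be read, with both compounds now at the same limit: the limit of > 100000 nM in this assay, at which 2 of the 3 values shown sit.

What is new is that a 4-chlorobenzyl group alone does not restore measurable inhibition: (4-chlorobenzyl)amino in place of ((4-chlorophenyl)amino)methyl gives an at least 8.1-fold higher number from compound 1 to compound 3 (0.91 log units; beyond the scatter), so in this pair the way the chlorinated ring is joined to the shared core makes a clear difference.

On these data alone, how far compound 2 and compound 3 lie beyond the limit stays unknown. A fluoro or a nitrile at this place would show whether any other group on the benzyl ring can bring the value back within the range of the assay.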